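The source may report more compounds than this note shows. Statements on the series, on what has been measured and on what is new or still open speak of the compounds shown alone.

Series notes, cytotoxicity.

Compound 1 `CC(=O)N1N=C(c2cccc3ccccc23)CC1c1ccco1` and compound 2 `COc1ccc(C2CC(c3cccc4ccccc34)=NN2C(C)=O)cc1` share a core and differ in one place: 4-methoxyphenyl in place of furan-2-yl on a saturated ring carbon. In a functional assay on OVCAR cells (Homo sapiens) for cytotoxicity, read by sulforhodamine B assay, with a stated time of 48 h (a higher number here means a weaker inhibitor, a lower number a stronger inhibitor), compound 1 gives 13000 nM, and compound 2 gives 6710 nM; the step is a 1.9-fold lower number from compound 1 to compound 2 (0.29 log units; within the scatter).

Compound 3 `O=CCN1N=C(c2ccc3ccccc3c2)CC1c1ccco1` has the same atoms as compound 1 joined differently; the difference between the two cores is not broken down here. In this assay compound 3 gives 18000 nM, within the scatter of compound 1 and beyond it only against compound 2.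

Compound 4 `COc1ccc(C2CC(c3ccc4ccccc4c3)=NN2CC=O)cc1` is not yet measured. It differs from compound 3 as follows: 4-methoxyphenyl in place of furan-2-yl on a saturated ring carbon. This is the same kind of change as that from compound 1 to compound 2, with one difference around the place: in compound 3 the ring atom bears a formylmethyl group where compound 1 bears an acetyl group.

The step from compound 3 to compound 4 in this assay is expected to be a 1.9-fold lower number from compound 3 to compound 4 (0.28 log units; within the scatter), resting on the measured step of a 1.9-fold lower number from compound 1 to compound 2 (0.29 log units; within the scatter) and taken as no firmer than that one step allows. Compound 4 is therefore estimated at 9500 nM, with a range from 4500 nM to 20000 nM.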

Compound 4, half-maximal inhibitory concentration: 5790 nM
The estimate for compound 4 lay 1.6-fold (0.22 log units) above the measured number; measured number inside the range.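

Notes on transfer. In this assay, 4-methoxyphenyl in place of furan-2-yl on the saturated ring carbon gives a 3.1-fold lower number from compound 3 to compound 4 (0.49 log units; beyond the scatter), and the two steps for this change do not differ: the same change on two cores in this assay, a 1.9-fold lower number (0.29 log units; within the scatter) from compound 1 to compound 2 and a 3.1-fold lower number (0.49 log units; beyond the scatter) from compound 3 to compound 4, 1.6-fold (0.21 log units) apart, within the scatter of two such steps.

Among these compounds, the change can therefore be carried from the core of compound 1 to the core of compound 3 with no measurable difference in step size, even though only the step on the core of compound 3 lies beyond the scatter. This rests on two pairs in one assay, so it does not establish a fixed step for the series, nor does it show what the difference between the two cores contributes.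

Open, going by these compounds, is whether a thiophen-2-yl or 4-hydroxyphenyl group on that saturated ring carbon would fit the same picture. Also open, on these data alone, is whether the step would hold with a carboxylic acid or a longer chain on the ring atom that bears the acetyl or formylmethyl group.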